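From methoxycarbonyl to carboxy at the assay limit

The source may hold more compounds than are shown below. What is called first, only, known or untested is meant among the compounds shown, and "the series" means these compounds.

Measured so far in an ADME assay on L02 cells (Homo sapiens) for antiproliferative activity, read by MTT assay, with a stated time of 48 h; a lower number here means a stronger inhibitor, a higher number a weaker inhibitor:
- Compound 1 `CCn1c(C(=O)NCC#N)ccc1C(CC)(CC)c1ccc(OCCC(O)(CC)CC)c(C)c1` gives > 50000 nM (a limit)
- Compound 2 `CCn1c(C(=O)NCCN)ccc1C(CC)(CC)c1ccc(OCCC(O)(CC)CC)c(C)c1` gives 2940 nM (a number)
- Compound 3 `CCC(C)C(NC(=O)c1ccc(C(CC)(CC)c2ccc(OCCC(O)(CC)CC)c(C)c2)n1CC)C(=O)OC` gives > 50000 nM (a limit)

Compound 3 has no exact number here and sits at the limit of > 50000 nM in this assay, at which 2 of the 3 values shown sit, with nothing more precise to go on. The change to compound 4 `CCC(C)C(NC(=O)c1ccc(C(CC)(CC)c2ccc(OCCC(O)(CC)CC)c(C)c2)n1CC)C(=O)O` is this: hydrogen in place of methyl on an oxygen next to a carbonyl group (methoxycarbonyl to carboxy).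

Among the measured compounds shown here, no measured step makes this same change. The steps available alter the group on the amide-type nitrogen instead: an at least 17-fold lower number from compound 1 to compound 2 (1.23 log units; beyond the scatter) and an at least 17-fold higher number from compound 2 to compound 3 (1.23 log units; beyond the scatter) are both large, while a step that the two limits leave unreadable from compound 1 to compound 3 cannot be sized. Only compound 2 reaches a number. Compound 4 keeps the group on the amide-type nitrogen that compound 3 carries, and compound 3 stands at > 50000 nM as a limit, so no step beyond the scatter is expected in this assay in either direction.

Compound 4 is estimated at 50000 nM with an expected range from 20000 nM to 100000 nM overall. The expected step is a number no higher from compound 3 to compound 4 (the limit leaves the size open) by this estimate.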

Compound 4, half-maximal inhibitory concentration: 9990 nM
For compound 4 the middle estimate is 5.0-fold (0.70 log units) above the measured one, and the stated range ends above it.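

In this assay, exchanging methyl for hydrogen on an oxygen next to a carbonyl group, which turns methoxycarbonyl into carboxy, gives an at least 5.0-fold lower number from compound 3 to compound 4 (0.69 log units; beyond the scatter), so this end of the group on the amide-type nitrogen clearly affects the read-out. Compound 3 stands at a limit and not at a number, so this step has only a lower bound: the limit of > 50000 nM in this assay, at which 2 of the 4 values shown sit. With 1-carboxy-2-methylbutyl, the series now has a second exact number, with an at least 5.0-fold lower number from compound 1 to compound 4 (0.69 log units; beyond the scatter) against cyanomethyl, yet 2-aminoethyl still gives the lower number, as a 3.4-fold higher number from compound 2 to compound 4 (0.53 log units; beyond the scatter) shows.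

From the compounds shown here alone, it remains open whether a primary amide or an ethyl ester in place of the carboxy would behave like the acid or like the methyl ester. Going by these compounds, it is also open whether a carboxy on a shorter chain, such as carboxymethyl, would give a lower number than compound 4.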